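The compounds below may be only part of what the source reports. "The series", "measured", "known", "first", "only" and "open" are said of these compounds alone.

Working notes on the series.

Compound 1 `C[C@@H](Nc1c(C(=O)NCc2ccc(F)cc2)nc(Br)c2cccnc12)c1ccccc1` carries the shared core with a 1-phenylethyl on a nitrogen on an aromatic ring whose other neighbours are aromatic carbon. In a functional assay on MCF7 cells (Homo sapiens) for cytotoxicity, read by MTT assay, with a stated time of 72 h (on this read-out higher numbers stand for weaker inhibition and lower numbers for stronger inhibition), compound 1 is recorded as "not determined" (no result reported), so compound 1 stands nowhere on the numbers shown; no potency can be read for it.

The only measured point in the series is compound 2 `N[C@H]1CC[C@H](Nc2c(C(=O)NCc3ccc(Oc4ccccc4)cc3)nc(Br)c3cccnc23)CC1`, which in this assay gives 7900 nM. Compound 2 differs from compound 1 at more than one place, so its value says nothing direct about the step to compound 3.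

Compound 3 `NCCCCCCNc1c(C(=O)NCc2ccc(F)cc2)nc(Br)c2cccnc12` is the target of the step from compound 1: 6-aminohexyl in place of 1-phenylethyl on a nitrogen on an aromatic ring. The change exchanges (1-phenylethyl)amino for (6-aminohexyl)amino. Compound 1 has no number in this assay, so neither the size nor the direction of this step can be stated; the expectation for compound 3 rests on compound 2 alone, which also carries a primary amine on the same nitrogen and gives 7900 nM. On that basis compound 3 is expected to give about 8000 nM in this assay, estimated between 2000 nM and 40000 nM.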

Compound 3, half-maximal inhibitory concentration: 2000 nM
Estimate against measurement, compound 3: 4.0-fold (0.60 log units) above; measured number inside the range.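

No new step can be read: compound 1 has no number, and compound 3 differs from compound 2 at more than one place. The compounds shown leave open how far, and in which direction, 6-aminohexyl in place of 1-phenylethyl moves potency on the shared core. No measurement shown bears on the result for compound 3.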